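Nitrophenyl Ketone Analogue Weighed Against Weakly Cytotoxic Ketones

The compounds below may be only part of what the source reports. "The series", "measured", "known", "first", "only" and "open" are said of these compounds alone.

Compound 1 `COc1cc(-c2nnc3n2NC(c2ccco2)C(C(=O)c2ccc(Br)cc2)S3)cc(OC)c1OC`: > 100000 nM, a limit of the assay.
Compound 2 `COc1cc(-c2nnc3n2NC(c2ccco2)C(C(=O)c2ccc(F)cc2)S3)cc(OC)c1OC`: > 100000 nM, likewise a limit.
Compound 3 `COc1cc(-c2nnc3n2NC(c2ccco2)C(C(=O)c2ccc(F)c(F)c2)S3)cc(OC)c1OC`: 73200 nM.

Among the measured compounds shown here, in a functional assay on MCF7 cells (Homo sapiens) for cytotoxicity, read by MTT assay, with a stated time of 48 h (on this read-out lower numbers stand for stronger inhibition and higher numbers for weaker inhibition), compound 3 carries the only number among the three; the other two sit at the limit of > 100000 nM in this assay, at which 2 of the 3 values shown sit. Compound 4 `COc1cc(-c2nnc3n2NC(c2ccco2)C(C(=O)c2ccc([N+](=O)[O-])cc2)S3)cc(OC)c1OC` arises from compound 3 through (4-nitrophenyl in place of 3,4-difluorophenyl on a carbonyl carbon). For the measured compounds named here, the steps that bear on it are an at least 1.3-fold lower number from compound 1 to compound 3 (0.13 log units; that floor lies within the scatter) and an at least 1.3-fold lower number from compound 2 to compound 3 (0.13 log units; that floor lies within the scatter), both floors lying within the scatter, while a step that the two limits leave unreadable from compound 1 to compound 2 cannot be read. Going by the values given here, no measured step therefore points to a change beyond the scatter in this assay, and compound 4 is expected near compound 3, at 75000 nM within 25000 nM to 100000 nM, which corresponds to an expected 1.0-fold higher number from compound 3 to compound 4 (0.01 log units; within the scatter).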

Compound 4, half-maximal inhibitory concentration: > 100000 nM
Compound 4: a limit, no number (the forecaster's own chance of this, stated with the estimate: 40%); middle value at least 1.3-fold (0.12 log units) away from the limit.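

In this assay, 4-nitrophenyl in place of 3,4-difluorophenyl on the carbonyl carbon gives an at least 1.3-fold higher number from compound 3 to compound 4 (0.13 log units; that floor lies within the scatter), so this change, like the earlier ones, shows no step beyond the scatter. The steps that link the three limits to one another cannot be read. With a nitro group now set beside the halogen-bearing rings at this position, the values still gather at a single point: the limit of > 100000 nM in this assay, at which 3 of the 4 values shown sit.

Going by these compounds, whether an amine or a carboxylic acid on this phenyl ring would give a number clearly lower than that of compound 3 stays open.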